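Aryl exchange on the shared core: notes toward compound 4

The source may report more compounds than this note shows. Statements on the series, on what has been measured and on what is new or still open speak of the compounds shown alone.

Measured in (a functional assay on A549 cells (Homo sapiens) for cytotoxicity, read by MTT assay, with a stated time of 72 h; on this read-out higher numbers stand for weaker inhibition and lower numbers for stronger inhibition):
- compound 1 `CNC(=O)c1cc(Oc2ccc(C3=NNC(c4ccc(F)cc4Cl)C3)cc2)ccn1` gives 13700 nM
- compound 2 `CNC(=O)c1cc(Oc2ccc(C3=NNC(c4ccc(OC)cc4)C3)cc2)ccn1` gives 13100 nM
- compound 3 `CNC(=O)c1cc(Oc2ccc(C3=NNC(c4ccc(Br)cc4)C3)cc2)ccn1` gives 21000 nM

Compound 3 stands level with the other two compounds, as these steps show: a 1.5-fold higher number from compound 1 to compound 3 (0.19 log units; within the scatter) and a 1.6-fold higher number from compound 2 to compound 3 (0.20 log units; within the scatter). Compound 4 `CNC(=O)c1cc(Oc2ccc(C3=NNC(c4cccc(Cl)c4Cl)C3)cc2)ccn1` is unmeasured and differs from compound 3 on a saturated ring carbon of the shared core, with 2,3-dichlorophenyl in place of 4-bromophenyl (2,3-dichlorophenyl in place of 4-bromophenyl on a saturated ring carbon). Three measured aryl exchanges on that same carbon bear on this change. The two above are joined by a third: a 1.0-fold lower number from compound 1 to compound 2 (0.02 log units; within the scatter). Among the compounds with values here, all three stay within the scatter, although no measured compound carries the 2,3-dichlorophenyl group. On that basis, no step beyond the scatter is expected in this assay. Compound 1, which gives 13700 nM, is the closest guide as the other chlorine-bearing compound. The step expected is a 1.4-fold lower number from compound 3 to compound 4 (0.15 log units; within the scatter). The estimated value for compound 4 is 15000 nM, with an expected range from 7500 nM to 30000 nM.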

Compound 4, half-maximal inhibitory concentration: 12100 nM
Estimate against measurement, compound 4: 1.2-fold (0.09 log units) above, within the range that was stated.
By their numbers in this assay, from the lowest: compounds 4, 2, 1 and 3 (each within the scatter of the next).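

The 2,3-dichlorophenyl group adds a fourth aryl group on this saturated ring carbon, and in this assay every step to it stays within the scatter (a 1.7-fold lower number from compound 3 to compound 4 (0.24 log units; within the scatter); a 1.1-fold lower number from compound 2 to compound 4 (0.03 log units; within the scatter); a 1.1-fold lower number from compound 1 to compound 4 (0.05 log units; within the scatter)). The flat picture therefore also holds for an aryl group carrying two chlorines, which enters with 8 heavy atoms where 4-bromophenyl leaves with 7, and none of the four compounds goes against it. Nothing on hand gives a reason for this flatness.

Going by these compounds, whether an aryl group carrying an amine or a carboxylic acid, or a longer chain in place of the aryl group, would give a step beyond the scatter stays open. The shown compounds also leave open any change elsewhere on the shared core, which is the same in all four.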